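A few compounds are considered here, and "the series" means these few. Any claim that something is new, unique, unknown or untested is made for them only; others in the source may bear on it.

Compound 1 `Cc1oc(-c2ccccc2Cl)nc1CN1CCC(C(=O)NCCCN2C[C@H](C)C[C@H](C)C2)CC1` is the longer-lived of the two compounds measured in an ADME assay on microsomes from liver (Rattus norvegicus) for metabolic stability, read by LC-MS, using NADPH, at 37 degrees C; on this read-out higher numbers stand for a longer-lived compound and lower numbers for a shorter-lived compound. In this assay, going by the values given here, compound 1 gives 0.25 h, and the only other measured compound, compound 2 `Cc1ccccc1-c1nc(CN2CCC(C(=O)NCCCN3CCCC(CC(C)C)C3)CC2)c(C)o1`, gives 0.0383 h in this assay; the two differ in several places at once, so their values show only that compound 1 stands well above compound 2, not which part of the molecule makes the difference.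

Compound 3 `Cc1ccc(-c2nc(CN3CCC(C(=O)NCCCN4C[C@H](C)C[C@H](C)C4)CC3)c(C)o2)cc1C` keeps the core of compound 1 and changes it in one place: 3,4-dimethylphenyl in place of 2-chlorophenyl on an aromatic carbon. Among the compounds with values here, no measured pair differs by this change alone, so the size and direction of the step cannot be read from a measured step.

The expectation rests mainly on compound 1 and its value of 0.25 h, the closest measured point. A modest step from compound 1 to compound 3 in this assay is expected, a 1.7-fold lower number from compound 1 to compound 3 (0.22 log units; within the scatter), toward a somewhat shorter-lived compound, and it may well fall within the usual scatter. Compound 3 is therefore estimated at 0.15 h in this assay, with a likely range from 0.05 h to 0.4 h.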

Compound 3, half-life: > 0.5 h
Compound 3: no number, only a limit; the forecaster's own chance of this, stated with the estimate: 5%; middle value at least 3.3-fold (0.52 log units) from the limit.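

In this assay compound 3 gives > 0.5 h, which is a limit of the assay and not a number, so only a floor is known: the limit of > 0.5 h in this assay, at which 1 of the 3 values shown sits.

Going by these compounds alone, exchanging 2-chlorophenyl for 3,4-dimethylphenyl on this aromatic carbon of the five-membered aromatic ring with 1 nitrogen and 1 oxygen gives an at least 2.0-fold higher number from compound 1 to compound 3 (0.30 log units; that floor lies within the scatter), the first step here that isolates a single place, since the two earlier compounds differ in several places at once. Although the printed floor of this step lies within the usual scatter, it shows that this position accepts a different substituted phenyl ring with the rest of compound 1 unchanged, with no shortening of the half-life in this pair.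

Within the data shown here, the single exchange removes the chlorine and adds two methyl groups together, so these compounds cannot tell which of those differences matters, or how far the half-life of compound 3 extends past the limit. Also open, going by these compounds, is how this position would respond to a ring other than phenyl, such as a pyridine, or to a smaller group such as a lone fluorine on the phenyl ring.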